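The source may hold more compounds than are shown below. What is called first, only, known or untested is meant among the compounds shown, and "the series" means these compounds.

Working notes on the triazine series

Of the compounds shown here, three carry numbers so far in a functional assay on L5178Y cells (Mus musculus) for inhibition; on this read-out higher numbers stand for higher potency (the scale is a negative logarithm) and lower numbers for lower potency. Compound 1 `CC1(C)N=C(N)N=C(N)N1c1ccc(OCc2cccc(C(N)=O)c2)c(Cl)c1` gives 7.53 in this assay. Compound 3 `CC(C)c1cccc(OCc2cccc(N3C(N)=NC(N)=NC3(C)C)c2)c1` gives 8.13 in this assay. Compound 2 `CC1(C)N=C(N)N=C(N)N1c1cccc(C(O)c2ccccc2)c1` gives 6.41 in this assay, and this is the lowest of the three numbers: the nearest number, that of compound 1, lies beyond the scatter above it, and the furthest, that of compound 3, lies still further above it. Among the compounds with values here, no pair of these three compounds differs in a single place, so no step between measured compounds is available as a guide.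

Compound 4 `CC1(C)N=C(N)N=C(N)N1c1cccc(S(N)(=O)=O)c1` is the next compound to go into this assay. It differs from compound 2 in one place: sulfamoyl in place of hydroxy(phenyl)methyl on an aromatic carbon. The group that enters is much smaller than the group that leaves, and nothing in the measured set shows how this assay responds to such a replacement on the shared core.

A modest loss, beyond the scatter, is expected for the step of a number 0.41 log units lower from compound 2 to compound 4 (beyond the scatter). Compound 4 is therefore estimated at 6 in this assay, with a range from 5.3 to 6.7, pending the measurement.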

Compound 4, logarithm of the reciprocal of the active concentration, log(1/C): 5.61
Compound 4: the middle estimate sits 0.39 log units above what was measured, within the range that was stated.
By their numbers in this assay, from the lowest: compound 4; then compound 2; then compound 1; then compound 3.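

In this assay, sulfamoyl in place of hydroxy(phenyl)methyl on an aromatic carbon, meta to a large group, gives a number 0.80 log units lower from compound 2 to compound 4 (beyond the scatter), the first step read at a single place on the shared core. The number at this position therefore depends on the group it carries, and here the exchange of 8 heavy atoms with a six-membered aromatic ring for 4 heavy atoms with no ring goes with a lower number, although this single step cannot show whether that holds for other groups. No measurement at hand bears on the origin of this step.

The step changes the size of the group, the presence of the ring and the kind of group all at once, so the compounds shown leave open which of these the lower number follows. Going by these compounds, a hydroxymethyl, a carboxylic acid or an amine at the same place on the shared core would help separate these, and whether the same replacement gives a step of similar size in other members also remains open.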